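The source may report more compounds than this note shows. Statements on the series, on what has been measured and on what is new or still open speak of the compounds shown alone.

Measured in an ADME assay on TZM cells (Homo sapiens) for cytotoxicity, read by XTT assay, with a stated time of 4 days (on this read-out lower numbers stand for higher toxicity in this test and higher numbers for lower toxicity in this test), each value being a limit:

- compound 1 `CNC(=O)c1cc(N)c(Nc2ccc(C#N)cc2)cc1Oc1c(C)cc(CCC#N)cc1C`: > 9100 nM
- compound 2 `Cc1cc(CCC#N)cc(C)c1Oc1cc(Nc2ccc(C#N)cc2)c(N)cc1CO`: > 23800 nM
- compound 3 `Cc1cc(CCC#N)cc(C)c1Oc1cc(Nc2ccc(C#N)cc2)c(N)cc1C(=O)NN`: > 22700 nM

Compound 3 therefore stands where the other two stand, with a limit and no number. The next compound, compound 4 `COC(=O)c1cc(N)c(Nc2ccc(C#N)cc2)cc1Oc1c(C)cc(CCC#N)cc1C`, has not yet been measured. It carries methoxy in place of aminoamino on a carbonyl carbon, which can also be read as aminocarbamoyl to methoxycarbonyl.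

For the measured compounds named here, two measured steps bear on this change, since each alters the same group of compound 3. One is a step that the two limits leave unreadable from compound 1 to compound 3, and the other is a step that the two limits leave unreadable from compound 2 to compound 3. Neither has a readable size, so they give no ground for expecting a shift in either direction. The estimate amounts to an at least 1.0-fold lower number from compound 3 to compound 4 (0.01 log units; that floor lies within the scatter), and no step beyond the usual scatter is expected. Compound 4 is estimated at 22000 nM, with an expected range of 8000 nM to 60000 nM, and it will probably be reported as a limit too.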

Compound 4, half-maximal cytotoxic concentration: > 22700 nM
Compound 4 ended at the assay's limit; the forecaster's own chance of this, stated with the estimate: 85%; middle value at least 1.0-fold (0.01 log units) away from the limit.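

In this assay, for the compounds shown here, compound 1, compound 2, compound 3 and compound 4 all stand as limits and not as numbers, so no step among them can be read. The compounds shown leave open whether the methylcarbamoyl, hydroxymethyl, aminocarbamoyl and methoxycarbonyl groups differ at all in this read-out.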